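Adding a Second Methoxy to Compound 2

The source may hold more compounds than are shown below. What is called first, only, known or untested is meant among the compounds shown, and "the series" means these compounds.

Of the compounds shown here, three sharing one core have been measured in a functional assay on Jurkat cells (Homo sapiens) for inhibition, read by MTT assay, with a stated time of 72 h; on this read-out lower numbers stand for stronger inhibition and higher numbers for weaker inhibition. Compound 1 (`C=C(Br)C(=O)Nc1cccc(/C=C/C(=O)Nc2cccc(F)c2)c1`) gives 1000 nM, compound 2 (`C=C(Br)C(=O)Nc1cccc(/C=C/C(=O)Nc2ccc(OC)cc2)c1`) gives 470 nM, and compound 3 (`C=C(Br)C(=O)Nc1cccc(/C=C/C(=O)Nc2ccc(SC(F)(F)F)cc2)c1`) gives 30100 nM. Compound 2 thus holds the lowest of the three numbers, with both other compounds higher by more than the scatter.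

Compound 4 (`C=C(Br)C(=O)Nc1cccc(/C=C/C(=O)Nc2ccc(OC)c(OC)c2)c1`) has not yet been measured. It differs from compound 2 by a single change: methoxy in place of hydrogen on an aromatic carbon, ortho to a methoxy group and meta to a large group.

Within the data shown here, two measured steps bear on this change. Putting 4-methoxyphenyl in place of 3-fluorophenyl on an amide-type nitrogen gave a 2.1-fold lower number from compound 1 to compound 2 (0.33 log units; beyond the scatter), a modest step. Putting (trifluoromethyl)sulfanyl in place of methoxy gave a 64-fold higher number from compound 2 to compound 3 (1.81 log units; beyond the scatter), a large one. Neither step adds a group while keeping the methoxy, so the data do not test this change directly. Compound 4 keeps the methoxy that was lost in a 64-fold higher number from compound 2 to compound 3 (1.81 log units; beyond the scatter), so a step of that size is not expected. The expected step is a 1.3-fold higher number from compound 2 to compound 4 (0.11 log units; within the scatter), slightly towards a higher number and probably within the scatter. For compound 4 the estimated value in this assay is 600 nM, with an expected range from 200 nM to 1800 nM.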

Compound 4, half-maximal inhibitory concentration: 190 nM
Estimate against measurement, compound 4: 3.2-fold (0.50 log units) above, outside the stated range (below it).
By their numbers in this assay, from the lowest: compound 4; then compound 2; then compound 1; then compound 3.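

The earlier steps shown here only exchanged one group for another, whereas this one adds a group and keeps the methoxy of compound 2. In this assay, methoxy in place of hydrogen on the aromatic carbon ortho to a methoxy group and meta to a large group gives a 2.5-fold lower number from compound 2 to compound 4 (0.39 log units; beyond the scatter), a modest step that shows this position accepts a second methoxy with a move towards stronger inhibition, and leaves compound 4 with the lowest number of the four compounds. Nothing shown here offers an explanation for this step.

On these data alone, whether the step belongs to methoxy in particular remains open, as a fluorine atom, a hydroxyl, an amine or the longer ethoxy chain on the same aromatic carbon would be needed to tell it apart from what other groups do there. As far as these compounds go, it is also open whether this carbon would give a step of the same size and direction with hydrogen in place of the first methoxy, that is, whether the two methoxy groups act together or separately.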